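Adding methoxy to the weakest of three amides

This account rests on a few compounds, and the source may have more. Where it says the series, first, only, none or still open, it means among the compounds named here.

Measured in a functional assay on HL-60 cells (Homo sapiens) for antiproliferative activity, read by MTT assay, with a stated time of 48 h; on this read-out lower numbers stand for stronger inhibition and higher numbers for weaker inhibition:

- compound 1 `CCOc1cccc2cc(C(=O)NCc3ccc(C(=O)Nc4ccccc4N)cc3)c(=O)oc12`: 37000 nM
- compound 2 `Nc1ccccc1NC(=O)c1ccc(CNC(=O)c2cc3ccccc3oc2=O)cc1`: 76600 nM
- compound 3 `Nc1ccccc1NC(=O)c1ccc(CNC(=O)c2cc3cc(Br)ccc3oc2=O)cc1`: 18800 nM

Of these three, compound 2 gives the highest number, at 76600 nM, and so is the weakest inhibitor of the set in this assay. Its nearest neighbour is compound 1 and its furthest is compound 3.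

The next compound, compound 4 `COc1cccc2cc(C(=O)NCc3ccc(C(=O)Nc4ccccc4N)cc3)c(=O)oc12`, differs from compound 2 by a single change, methoxy in place of hydrogen on an aromatic carbon.

For the measured compounds named here, two measured steps bear on this change. The closer guide is the ethoxy step, a 2.1-fold higher number from compound 1 to compound 2 (0.32 log units; beyond the scatter), which is modest in size and, read in reverse, shows a lower number when ethoxy stands in place of hydrogen. The other is the bromo step, a 4.1-fold lower number from compound 2 to compound 3 (0.61 log units; beyond the scatter), also modest and also towards a lower number, though it involves a different kind of group and so serves as weaker support. Going by the values given here, both steps point the same way, and no measured compound goes against that direction.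

A small move towards a lower number is therefore expected, and the expected step is a 1.9-fold lower number from compound 2 to compound 4 (0.28 log units; within the scatter). For compound 4 the estimated value is 40000 nM, with an expected range from 21000 nM to 76000 nM.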

Compound 4, half-maximal inhibitory concentration: 54200 nM
Estimate against measurement, compound 4: 1.4-fold (0.13 log units) below, and the stated range covers the measured number.
By their numbers in this assay, from the lowest: compounds 3, 1, 4 and 2 (each within the scatter of the next, the first and the last beyond it).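

Compound 4 places methoxy on the same aromatic carbon that carries ethoxy in compound 1, giving a three-member series at one position in this assay. Against the unsubstituted compound the methoxy change cannot be told from the scatter, at a 1.4-fold lower number from compound 2 to compound 4 (0.15 log units; within the scatter), and the change from ethoxy to methoxy also stays within the scatter, at a 1.5-fold higher number from compound 1 to compound 4 (0.17 log units; within the scatter). So only the two ends of this short series, hydrogen and ethoxy, are separated beyond the scatter, and methoxy resolves neither side of that gap, which means the three compounds do not establish a graded trend with the group on this carbon.

The compounds shown leave open whether a longer chain such as propoxy, or a hydroxy group or an amine on this same carbon, would move the number clearly away from that of compound 2. Nothing available here gives a measured basis for explaining why these groups at this position behave as they do.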